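The source may report more compounds than this note shows. Statements on the series, on what has been measured and on what is new or still open speak of the compounds shown alone.

Going by the values given here, compound 2 `Cc1ccc(Oc2nc(Nc3ccc(C#N)cc3)nc3ccccc23)cc1` is one of two compounds measured in an ADME assay on MT4 cells (Homo sapiens) for cytotoxicity, read by MTT assay, with a stated time of 4 days; on this read-out lower numbers stand for higher toxicity in this test and higher numbers for lower toxicity in this test; in this assay compound 2 gives 87000 nM, the lower of the two numbers, while compound 1 `COc1ccccc1Oc1nc(Nc2ccc(C#N)cc2)nc2ccccc12` gives 150000 nM. Among the compounds with values here, the single step on record, a 1.7-fold lower number from compound 1 to compound 2 (0.24 log units; within the scatter), stays within the scatter. Compound 3 `Cc1ccccc1Oc1nc(Nc2ccc(C#N)cc2)nc2ccccc12` has not yet been measured in this assay. It differs from compound 2 by 2-methylphenyl in place of 4-methylphenyl on an oxygen on an aromatic ring; the two have the same atoms, joined differently. Within the data shown here, only the step from compound 1 to compound 2 bears on this change, since it also exchanges the ring on the same oxygen, and that step was small. For the change from compound 2 to compound 3 no step beyond the scatter is therefore expected in this assay. The expected step is a 1.1-fold higher number from compound 2 to compound 3 (0.06 log units; within the scatter). Compound 3 is accordingly estimated to give about 100000 nM, within a range from 40000 nM to 250000 nM.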

Compound 3, half-maximal cytotoxic concentration: 355000 nM
Compound 3: the middle estimate sits 3.6-fold (0.55 log units) below what was measured, outside the stated range (above it).
By their numbers in this assay, from the lowest: compounds 2 and 1 (each within the scatter of the next); then compound 3.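

The position of the methyl group on this ring counts in this assay: with 2-methylphenyl in place of 4-methylphenyl on an oxygen on an aromatic ring, the record shows (a 4.1-fold higher number from compound 2 to compound 3 (0.61 log units; beyond the scatter)), so two groups with the same atoms are separated beyond the scatter, with the higher number standing for lower toxicity in this test. Methyl in place of methoxy on an aromatic carbon also gives a step beyond the scatter (a 2.4-fold higher number from compound 1 to compound 3 (0.37 log units; beyond the scatter)), whereas the only earlier step stayed within it. Nothing measured here accounts for either step.

The compounds shown leave open whether the higher number is tied to the methyl itself or would persist with a longer chain such as ethyl, or with an amine, in its place. They also leave open whether the same change would have a similar effect on a different core.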